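Aryl variation on the saturated ring carbon of the core

The source may report more compounds than this note shows. Statements on the series, on what has been measured and on what is new or still open speak of the compounds shown alone.

Among the measured compounds shown here, compound 2 `CS(=O)(=O)c1ccc(C2=NN(c3ccc(S(N)(=O)=O)cc3)C(c3ccc(F)cc3)C2)cc1` gives 65.7% in a functional assay on the whole organism for inhibition, with Rattus norvegicus as the target, read by paw edema, with a stated time of 3 h, at a dose of 50 mg/kg by the oral route (a higher number here means more inhibition at the dose given (going by the name of the read-out), a lower number less inhibition), the higher of the two numbers so far; compound 1 `CS(=O)(=O)c1ccc(C2=NN(c3ccc(S(N)(=O)=O)cc3)C(c3ccccc3)C2)cc1` gives 54.3%. For the measured compounds named here, the only measured step, a number 11.4 percentage points higher from compound 1 to compound 2 (beyond the scatter), concerns this same ring carbon. Compound 3 `COc1cccc(C2CC(c3ccc(S(C)(=O)=O)cc3)=NN2c2ccc(S(N)(=O)=O)cc2)c1` differs from compound 2 by 3-methoxyphenyl in place of 4-fluorophenyl on a saturated ring carbon. Going by the values given here, no measured step involves a methoxy group, so the earlier fluoro gain need not carry over. Compound 3 is therefore expected to sit between the two measured values, estimated at 58% with a range of 40% to 72%. The expected step of a number 7.7 percentage points lower from compound 2 to compound 3 (within the scatter) stays within the scatter.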

Compound 3, a percentage reported as inhibition, in the whole organism at one dose (the size of the read-out at that dose, not a potency): 38.3%
Estimate against measurement, compound 3: 19.7 percentage points above; measured number below the stated range.
By their numbers in this assay, from the lowest: compound 3; then compound 1; then compound 2.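

In this assay, the aryl group on this saturated ring carbon can lower the read-out as well as raise it: 3-methoxyphenyl in place of 4-fluorophenyl gives a number 27.4 percentage points lower from compound 2 to compound 3 (beyond the scatter), and methoxy in place of hydrogen gives a number 16 percentage points lower from compound 1 to compound 3 (beyond the scatter). The loss therefore goes beyond the absence of the fluoro gain, since compound 3 also lies under the unsubstituted phenyl of compound 1. No available evidence explains this drop.

Still open, as far as these compounds go, is whether the loss follows the methoxy group itself or its place on the ring. Also open, from the compounds shown here alone, is how a hydroxy group or an amine on this aryl ring would compare.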